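Sulfonyl aryl swap on the larger amine ring

The source may hold more compounds than are shown below. What is called first, only, known or untested is meant among the compounds shown, and "the series" means these compounds.

Measured so far:
compound 1 `O=S(=O)(c1ccccc1F)c1cn(C2CCNC2)c2ncccc12` — 50 nM
compound 2 `O=S(=O)(c1ccc(Cl)cc1)c1cn(C2CCCNC2)c2ncccc12` — 682 nM

In a functional assay on HeLa cells for antagonist activity at 5-hydroxytryptamine receptor 6 (Homo sapiens), read by cAMP accumulation and immunoassay (on this read-out lower numbers stand for stronger inhibition and higher numbers for weaker inhibition), compound 1 gives 50 nM, and in this assay compound 2 gives 682 nM. Compound 2 therefore holds the highest number of the two; compound 1 sits well below it, and the gap between them lies beyond the scatter.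

The next compound, compound 3 `O=S(=O)(c1ccccc1F)c1cn(C2CCCNC2)c2ncccc12`, keeps the core and the saturated amine ring of compound 2 and changes only the aryl group: 2-fluorophenyl in place of 4-chlorophenyl on a sulfonyl sulfur. The 2-fluorophenyl that enters is the same aryl group carried by compound 1, the compound with the lower number.

Among the measured compounds shown here, no step between measured compounds isolates this change, so its size is open. Given that compound 1 gives 50 nM with the 2-fluorophenyl group, compound 3 is expected to move downward, with the step of a 3.8-fold lower number from compound 2 to compound 3 (0.58 log units; beyond the scatter) beyond the scatter. Compound 3 is estimated at 180 nM, within 45 nM to 700 nM.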

Compound 3, half-maximal inhibitory concentration: 50 nM
The estimate for compound 3 lay 3.6-fold (0.56 log units) above the measured number, within the range that was stated.
By their numbers in this assay, from the lowest: compounds 1 and 3 (each within the scatter of the next); then compound 2.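

In this assay, with piperidin-3-yl held fixed, 2-fluorophenyl in place of 4-chlorophenyl on a sulfonyl sulfur gives a 14-fold lower number from compound 2 to compound 3 (1.13 log units; beyond the scatter), so the aryl group at this position has a large effect on the number. With 2-fluorophenyl held fixed, piperidin-3-yl in place of pyrrolidin-3-yl on an aromatic nitrogen gives no change at the digits printed from compound 1 to compound 3 (within the scatter), so this pair shows no effect of the amine ring change. Nothing available explains the size of the aryl step.

The swap changes both the halogen and its place on the phenyl ring, and a 4-fluorophenyl or 2-chlorophenyl group would be needed to separate the two. From the compounds shown here alone, whether the amine ring change stays without effect alongside 4-chlorophenyl, or whether an open-chain aminoethyl group behaves like either ring, remains open.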